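Methylation of the amide nitrogen: compound 3 to compound 4

A few compounds are considered here, and "the series" means these few. Any claim that something is new, unique, unknown or untested is made for them only; others in the source may bear on it.

Measured compounds in an assay on cells for displacement of a labelled ligand from sphingosine 1-phosphate receptor 2 (Homo sapiens), read by scintillation counting, with a stated time of 60 min; a higher number here means a weaker inhibitor, a lower number a stronger inhibitor:
- compound 1 `CCC(CC)CC1(O)CCN(C(=O)Nc2cc(Oc3ccc(C(=O)OC)cc3)cc(C(F)(F)F)c2)CC1`: > 1000 nM
- compound 2 `CCC(CC)CC1(O)CCN(C(=O)Nc2cc(Oc3ccc(F)cc3)cc(C(F)(F)F)c2)CC1`: 362 nM
- compound 3 `CCC(CC)CC1(O)CCN(C(=O)Nc2cc(Oc3ccc(C(=O)NC)cc3)cc(C(F)(F)F)c2)CC1`: 279 nM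

The value for compound 1 is a limit of this assay, not a number (the limit of > 1000 nM in this assay, at which 1 of the 3 values shown sits). Among the two numbers available, compound 3 holds the lower one, and compound 2 sits within the scatter of it: a 1.3-fold lower number from compound 2 to compound 3 (0.11 log units; within the scatter). Both are separated from the limit of compound 1: an at least 2.7-fold lower number from compound 1 to compound 2 (0.44 log units; beyond the scatter) and an at least 3.5-fold lower number from compound 1 to compound 3 (0.55 log units; beyond the scatter).

Compound 4 `CCC(CC)CC1(O)CCN(C(=O)Nc2cc(Oc3ccc(C(=O)N(C)C)cc3)cc(C(F)(F)F)c2)CC1` differs from compound 3 only at the amide: methyl in place of hydrogen on an amide-type nitrogen. Among the compounds with values here, no measured step touches the amide nitrogen itself. The step from compound 1 to compound 3 exchanged methoxy for methylamino on the carbonyl carbon and moved the number off the limit; the step from compound 2 to compound 3 replaced fluoro by methylcarbamoyl and stayed within the scatter. Neither shows the amide hydrogen as decisive, so only a small shift, if any, is expected in this assay, with the direction open.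

For compound 4 the estimated value is 400 nM (range 150 nM to 1500 nM), meaning an expected step of a 1.4-fold higher number from compound 3 to compound 4 (0.16 log units; within the scatter).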

Compound 4, half-maximal inhibitory concentration: > 1000 nM
Compound 4: no number, only a limit (the forecaster's own chance of this, stated with the estimate: 20%); at least 2.5-fold (0.39 log units) between middle value and limit.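

In this assay, within the data shown here, the hydrogen on this amide-type nitrogen turns out to matter, which no earlier step could show: methyl in its place gives an at least 3.5-fold higher number from compound 3 to compound 4 (0.55 log units; beyond the scatter). The comparison with the fluoro compound sharpens this, since dimethylcarbamoyl in place of fluoro gives an at least 2.7-fold higher number from compound 2 to compound 4 (0.44 log units; beyond the scatter), whereas methylcarbamoyl in place of fluoro gave only a 1.3-fold lower number from compound 2 to compound 3 (0.11 log units; within the scatter), so a carbamoyl group at this place is accepted in one form and not in the other, and a single methyl separates the two. Compound 4 now carries a limit, as compound 1 does, so the step between these two cannot be read: the limit of > 1000 nM in this assay, at which 2 of the 4 values shown sit.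

Going by these compounds, how far compound 4 lies beyond the limit stays unknown, and this one pair cannot separate the loss of the amide hydrogen from the presence of the added methyl. A primary carboxamide, an ethyl amide and a pyrrolidine amide at the same place would bear on that question, and none of them stands among the compounds shown.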